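A few compounds are considered here, and "the series" means these few. Any claim that something is new, unique, unknown or untested is made for them only; others in the source may bear on it.

In a functional assay on cells (Homo sapiens) for cytotoxicity, read by MTT assay, with a stated time of 24 h (on this read-out higher numbers stand for weaker inhibition and lower numbers for stronger inhibition), compound 1 `CCCCCCCCCCCCCCNC(=O)[C@H](CO)/N=C/c1cccc(C)c1` gives 82900 nM and compound 2 `CCCCCCCCCCCCCCNC(=O)[C@H](CO)/N=C/c1ccccc1` gives 7670 nM as the lowest of the two numbers. Compound 3 `CCCCCCCCCCCCCCNC(=O)[C@H](CO)/N=C/c1ccc([N+](=O)[O-])cc1` has no number yet. It differs from compound 2 by nitro in place of hydrogen on an aromatic carbon in the phenyl to 4-nitrophenyl change, with nitro in place of hydrogen on an aromatic carbon, para to a large group. For the measured compounds named here, the only measured step that bears on this is an 11-fold lower number from compound 1 to compound 2 (1.03 log units; beyond the scatter) with hydrogen in place of methyl on an aromatic carbon, a large step beyond the scatter. In that pair the compound with the added ring group holds the higher number, so a higher number for compound 3 is the likelier direction. Methyl and nitro are different groups, no nitro compound has been measured, and one pair sets no pattern, so a smaller step than that one is expected, with wide uncertainty. In this assay the expected step is a 2.0-fold higher number from compound 2 to compound 3 (0.29 log units; within the scatter). For compound 3 the estimated value is 15000 nM with an expected range from 4000 nM to 60000 nM on this read-out.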

Compound 3, half-maximal inhibitory concentration: 217000 nM
Compound 3: the middle estimate sits 14-fold (1.16 log units) below what was measured; the whole stated range lies below it.
By their numbers in this assay, from the lowest: compound 2; then compound 1; then compound 3.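

In this assay, nitro on the aromatic carbon para to a large group gives a 28-fold higher number from compound 2 to compound 3 (1.45 log units; beyond the scatter), which is a large step and leaves compound 2 with the strongest inhibition of the three. Both ring groups shown, 3-methylphenyl in compound 1 and 4-nitrophenyl in compound 3, therefore sit on the weaker side of the unsubstituted phenyl, with no compound here going against this, and the two substituted compounds are themselves separated by a 2.6-fold higher number from compound 1 to compound 3 (0.42 log units; beyond the scatter), a modest step that remains beyond the scatter. No measurement offered here accounts for the size of either step.

The step between compound 1 and compound 3 changes both the group and its place on the ring, so these compounds cannot show how much of the difference belongs to nitro and how much to the position. Going by these compounds, whether the weakening extends to other groups also stays open, such as an amine, a carboxylic acid or a methoxy group at that same ring position, and whether it persists with a shorter chain in place of the present one on the amide nitrogen.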